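The compounds below may be only part of what the source reports. "The series", "measured", "known", "first", "only" and "open" are said of these compounds alone.

In an ADME assay on microsomes from liver (Homo sapiens) for metabolic stability (a higher number here means faster removal of the compound, a lower number slower removal), compound 3 `Cc1nc(N)nc2c1cc(-c1cn[nH]c1)c(=O)n2[C@H]1CC[C@H](OCO)CC1` gives < 8 mL.min-1.g-1, which is a limit and not a number. Compound 2 `COc1ncc(-c2cc3c(C)nc(N)nc3n([C@H]3CC[C@H](OCO)CC3)c2=O)cc1F` gives < 8 mL.min-1.g-1, which is also a limit. Going by the values given here, the only measured step, a step that the two limits leave unreadable from compound 2 to compound 3, therefore offers no size to carry forward. Compound 4 `Cc1nc(N)nc2c1cc(-c1cnc3ccccc3c1)c(=O)n2[C@H]1CC[C@H](OCO)CC1` is made from compound 3 by one change: quinolin-3-yl in place of 1H-pyrazol-4-yl on an aromatic carbon. Among the compounds with values here, the one measured number with quinolin-3-yl in place comes from a compound that is not identical to compound 4: compound 1 `Cc1nc(N)nc2c1cc(-c1cnc3ccccc3c1)c(=O)n2[C@H]1CC[C@@H](OCO)CC1` gives 105 mL.min-1.g-1. On that single value, the expected step is an at least 5.0-fold higher number from compound 3 to compound 4 (0.69 log units; beyond the scatter), towards faster removal, though its size is uncertain. Compound 4 is estimated at 40 mL.min-1.g-1, with an expected range of 12 mL.min-1.g-1 to 110 mL.min-1.g-1.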

Compound 4, intrinsic clearance in microsomes: < 8 mL.min-1.g-1
Compound 4: a limit, no number; the forecaster's own chance of this, stated with the estimate: 12%; at least 5.0-fold (0.69 log units) between middle value and limit.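

In this assay, quinolin-3-yl at this position does not by itself bring fast removal: the configuration as drawn on the saturated ring matters, with an at least 13-fold lower number from compound 1 to compound 4 (1.11 log units; beyond the scatter). This large step can be tied to configuration alone: the fact that compounds 1 and 4 differ only in the configuration as drawn

The steps among compound 2, compound 3 and compound 4 cannot be read, since all three sit at a limit: the limit of < 8 mL.min-1.g-1 in this assay, at which 3 of the 4 values shown sit.

From the compounds shown here alone, whether 1H-pyrazol-4-yl or 5-fluoro-6-methoxypyridin-3-yl would also give faster removal in the configuration of compound 1 stays open. So does what an amine or a carboxylic acid at this position would do.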